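This account rests on a few compounds, and the source may have more. Where it says the series, first, only, none or still open, it means among the compounds named here.

In an ADME assay on THP-1 cells (Homo sapiens) for cytotoxicity, read by MTT assay (a lower number here means that less compound is tolerated, a higher number that more compound is tolerated), compound 1 `COc1ccc2oc(-c3cccc(-c4ccc(OC)c(OC)c4)c3)c(O)c(=O)c2c1` shows only a limit (>= 25000 nM). Compound 2 `O=c1c(O)c(-c2cccc(-c3ccc(O)c(O)c3)c2)oc2ccc(O)cc12` likewise shows only a limit (>= 25000 nM). Compound 3 `COc1ccc2oc(-c3csc4ccccc34)c(OC(C)=O)c(=O)c2c1` is the starting point here and also shows only a limit (>= 12500 nM). Compared with compound 3, compound 4 `COc1ccc2oc(-c3csc4ccccc34)c(OC(=O)C(C)(C)C)c(=O)c2c1` has tert-butyl in place of methyl on a carbonyl carbon. Among the measured compounds shown here, no measured pair of compounds shows this kind of swap. For the measured compounds named here, the only guide is compound 3 and its limit (>= 12500 nM). The estimated step (a step that the limit leaves unreadable from compound 3 to compound 4) is expected to stay within the usual scatter in this assay, with no firm direction. The expected value for compound 4 is 18000 nM (estimated range 7000 nM to 40000 nM).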

Compound 4, half-maximal cytotoxic concentration: >= 12500 nM
Compound 4: a limit, no number (the forecaster's own chance of this, stated with the estimate: 75%); the middle value lies beyond the limit too.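

Compound 3 and compound 4 both give only limits in this assay, and the step between them cannot be read. The compounds shown leave open whether tert-butyl in place of methyl changes the concentration tolerated.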